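The source may hold more compounds than are shown below. What is called first, only, known or untested is meant among the compounds shown, and "the series" means these compounds.

Measured so far:
compound 1 `CCCCOCCn1c(N2CCCN(C)CC2)nc2ccccc21`, in a functional assay on ileum for inhibition of histamine H1 receptor (Cavia porcellus) (a lower number here means a stronger inhibitor, a higher number a weaker inhibitor), compound 1 gives 10 nM;
compound 2 `CCOCCn1c(N2CCN(C)CC2)nc2ccccc21`, in this assay compound 2 gives 10 nM;
compound 3 `CCCCN1CCCN(c2nc3ccccc3n2CCOCC)CC1`, in this assay compound 3 gives 8.4 nM.

Compound 2 stands level with compound 1 at the digits shown, the two together at the upper end of the three numbers, and its gap to compound 3 is within the scatter, so all three sit together. Compound 4 `CCSCCn1c(N2CCN(C)CC2)nc2ccccc21` differs from compound 2 by ethylsulfanyl in place of ethoxy on a saturated chain carbon, two bonds along the chain from an aromatic nitrogen. Among the compounds with values here, no measured pair isolates this exchange, so its size is not known from these numbers; the writer expects at most a small step in this assay, none beyond the scatter. Compound 4 is estimated to give 12 nM, within 4 nM to 40 nM. That estimate amounts to an expected step of a 1.2-fold higher number from compound 2 to compound 4 (0.08 log units; within the scatter).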

Compound 4, half-maximal inhibitory concentration: 19 nM
Estimate against measurement, compound 4: 1.6-fold (0.20 log units) below, and the stated range covers the measured number.
By their numbers in this assay, from the lowest: compounds 3, 1, 2 and 4 (each within the scatter of the next, the first and the last beyond it).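

In this assay, ethylsulfanyl in place of ethoxy on a saturated chain carbon, two bonds along the chain from an aromatic nitrogen, gives a 1.9-fold higher number from compound 2 to compound 4 (0.28 log units; within the scatter). Within the data shown here, this is the first pair to isolate the exchange, and it shows that sulfur can stand in for the oxygen of this chain without a step beyond the scatter. Nothing shown offers an explanation for this step.

As far as these compounds go, it remains open how a hydroxyl or a dimethylamino group would fare in this place. From the compounds shown here alone, whether the same exchange gives a similar step on the core of compound 3 is also open.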